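From Cyclobutylmethyl to 1-(Methoxymethyl)ethyl on a Shared Core

A few compounds are considered here, and "the series" means these few. Any claim that something is new, unique, unknown or untested is made for them only; others in the source may bear on it.

In an in vitro ADME assay on microsomes (Homo sapiens) for metabolic stability (on this read-out lower numbers stand for slow clearance and higher numbers for fast clearance), compound 1 `O=C(CN(CC1CC1)C(=O)c1ccc(-c2ccccn2)cc1)Nc1cc(F)cc(F)c1` reads < 0.5 mL.min-1.g-1, which is a limit of the assay and not a number. Compound 3 `O=C(CN(CC1CCC1)C(=O)c1ccc(-c2ccccn2)cc1)Nc1cc(F)cc(F)c1` gives 2 mL.min-1.g-1, and compound 2 `O=C(CN(C(=O)c1ccc(-c2ccccn2)cc1)C1CCCOC1)Nc1cc(F)cc(F)c1` gives 2.9 mL.min-1.g-1. These two stand level, with a 1.5-fold lower number from compound 2 to compound 3 (0.16 log units; within the scatter). The steps out of the limit are an at least 5.8-fold higher number from compound 1 to compound 2 (0.76 log units; beyond the scatter) and an at least 4.0-fold higher number from compound 1 to compound 3 (0.60 log units; beyond the scatter).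

Compound 4 `COCC(C)N(CC(=O)Nc1cc(F)cc(F)c1)C(=O)c1ccc(-c2ccccn2)cc1` carries 1-(methoxymethyl)ethyl in place of cyclobutylmethyl on an amide-type nitrogen. The closest measured swap exchanges cyclobutylmethyl and oxan-3-yl at that same nitrogen, and compound 2, whose group also holds oxygen, shows only a 1.5-fold lower number from compound 2 to compound 3 (0.16 log units; within the scatter). The larger steps start from the limit of compound 1 and concern cyclopropylmethyl, a group absent from compound 4, so they bear less on this change. No step beyond the scatter is therefore expected, and the estimate is a 1.5-fold higher number from compound 3 to compound 4 (0.18 log units; within the scatter). Compound 4 is expected at 3 mL.min-1.g-1, with an estimated range from 1 mL.min-1.g-1 to 8 mL.min-1.g-1.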

Compound 4, intrinsic clearance in microsomes: 5.8 mL.min-1.g-1
Beside the measured number, compound 4's estimate is 1.9-fold (0.29 log units) below it; the measured number falls inside the stated range.
By their numbers in this assay, from the lowest: compounds 3, 2 and 4 (each within the scatter of the next, the first and the last beyond it). At a limit, below all of these: compound 1.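

Swapping cyclobutylmethyl for 1-(methoxymethyl)ethyl on the amide-type nitrogen gives, in this assay, a 2.9-fold higher number from compound 3 to compound 4 (0.46 log units; beyond the scatter), so two groups that each hold 5 heavy atoms can be told apart at this position, which the level pair of compound 2 and compound 3 did not show. Set against the oxan-3-yl group, which also holds an oxygen, the change gives a 2.0-fold higher number from compound 2 to compound 4 (0.30 log units; within the scatter), so the two oxygen-bearing groups stand level and compound 2 also stands level with compound 3. The remaining step, an at least 11-fold higher number from compound 1 to compound 4 (1.06 log units; beyond the scatter), starts from a limit and not a number: the limit of < 0.5 mL.min-1.g-1 in this assay, at which 1 of the 4 values shown sits.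

As far as these compounds go, what stays open is whether a plain isobutyl chain, without the oxygen and without a ring, would fall with compound 3 or with compound 4. The compounds shown also leave open how a 2-(dimethylamino)ethyl chain on this nitrogen would read.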